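A Shorter Amide Group at the Limit of Measurement

A few compounds are considered here, and "the series" means these few. Any claim that something is new, unique, unknown or untested is made for them only; others in the source may bear on it.

In a functional assay on HepG2 cells (Homo sapiens) for antiproliferative activity, read by MTT assay, with a stated time of 48 h (on this read-out lower numbers stand for stronger inhibition and higher numbers for weaker inhibition), compound 1 (`CCn1c(C(=O)NCC#N)ccc1C(CC)(CC)c1ccc(OCCC(O)(CC)CC)c(C)c1`) stands at > 50000 nM as a limit and not as a number. In this assay compound 2 (`CCOC(=O)C(CC(=O)OC)NC(=O)c1ccc(C(CC)(CC)c2ccc(OCCC(O)(CC)CC)c(C)c2)n1CC`) stands at > 50000 nM and this too is only a limit. Both readings therefore sit at the same ceiling (the limit of > 50000 nM in this assay, at which 2 of the 2 values shown sit) and neither gives a measured potency.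

Compound 3 (`CCn1c(C(=O)N(C)CCO)ccc1C(CC)(CC)c1ccc(OCCC(O)(CC)CC)c(C)c1`) keeps the shared core but carries (2-hydroxyethyl)(methyl)amino on a carbonyl carbon (a group of 5 heavy atoms (3 carbon, 1 nitrogen, 1 oxygen; no ring) in place of a group of 12 heavy atoms (7 carbon, 1 nitrogen, 4 oxygen; no ring), on a carbonyl carbon). A group of 5 heavy atoms thus takes the place of a group of 12 heavy atoms.

Within the data shown here, the one measured step that bears on this change (a step that the two limits leave unreadable from compound 1 to compound 2) also alters the amide side of the molecule, but it has no readable size. Compound 2 remains at its limit (> 50000 nM) and so no step beyond the scatter is expected in this assay for this exchange. The expected move is a number no higher from compound 2 to compound 3 (the limit leaves the size open) and it remains only an estimate. For compound 3 the estimated value is 50000 nM with an expected range of 20000 nM to 100000 nM in this read-out.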

Compound 3, half-maximal inhibitory concentration: 510 nM
The estimate for compound 3 lay 98-fold (1.99 log units) above the measured number; the whole stated range lies above it.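

In this assay the earlier step on the amide side cannot be read, and that place gave no size of its own, with compounds at one ceiling: the limit of > 50000 nM in this assay, at which 2 of the 3 values shown sit. Compound 3 comes off that ceiling, with an at least 98-fold lower number from compound 2 to compound 3 (1.99 log units; beyond the scatter) for a group of 5 heavy atoms in place of a group of 12 heavy atoms, and with an at least 98-fold lower number from compound 1 to compound 3 (1.99 log units; beyond the scatter) for (2-hydroxyethyl)(methyl)amino in place of (cyanomethyl)amino on the same carbonyl carbon. So the group on this carbonyl carbon can decide the read-out with the shared core unchanged, yet a smaller group alone does not account for it, for compound 1 also carries a smaller group than compound 2 and still stands only at a limit.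

The compounds shown leave open whether the hydroxyl end of (2-hydroxyethyl)(methyl)amino or the methyl on its nitrogen goes with the lower number. On these data alone, how a morpholine or a longer hydroxyalkyl chain would read on this carbonyl carbon also stays open.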